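From Methoxy to Hydroxy on Compound 3

A few compounds are considered here, and "the series" means these few. Any claim that something is new, unique, unknown or untested is made for them only; others in the source may bear on it.

In a functional assay on KB-VIN10 cells (Homo sapiens) for inhibition, with a stated time of 72 h (a lower number here means a stronger inhibitor, a higher number a weaker inhibitor), compound 3 `COc1ccc(-c2cccc3c2N(S(=O)(=O)c2ccc(OC)cc2)CC3)cc1` gives 352 nM, the highest of the three numbers, against compound 1 `COc1ccc(S(=O)(=O)N2CCc3cccc(-c4ccco4)c32)cc1` at 79.2 nM and compound 2 `COc1ccc(S(=O)(=O)N2CCc3cccc(-c4ccc([N+](=O)[O-])cc4)c32)cc1` at 51.3 nM. Compound 4 `COc1ccc(S(=O)(=O)N2CCc3cccc(-c4ccc(O)cc4)c32)cc1` carries hydrogen in place of methyl on an oxygen on an aromatic ring, turning methoxy into hydroxy. For the measured compounds named here, no measured step makes this exact change. The closest are a 6.9-fold higher number from compound 2 to compound 3 (0.84 log units; beyond the scatter) and a 4.4-fold higher number from compound 1 to compound 3 (0.65 log units; beyond the scatter), both modest, which show that this part of the molecule can move the number. They give no direction for the new change, though compound 3 sits highest, so a small fall is expected. The expected step is a 1.4-fold lower number from compound 3 to compound 4 (0.15 log units; within the scatter). For compound 4 the estimated value is 250 nM, with an expected range from 80 nM to 800 nM.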

Compound 4, half-maximal inhibitory concentration: 123 nM
Compound 4: middle estimate off by 2.0-fold (0.31 log units), on the high side; the range from low to high includes it.
By their numbers in this assay, from the lowest: compounds 2, 1 and 4 (each within the scatter of the next, the first and the last beyond it); then compound 3.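

Taking only the methyl off the oxygen gives a 2.9-fold lower number from compound 3 to compound 4 (0.46 log units; beyond the scatter) and is the first direct reading of this change, showing that this one small edit can shift the number without altering the rest of the molecule. Hydroxy still trails nitro, with a 2.4-fold higher number from compound 2 to compound 4 (0.38 log units; beyond the scatter) in that comparison, whereas 4-hydroxyphenyl and furan-2-yl cannot be told apart, with a 1.6-fold higher number from compound 1 to compound 4 (0.19 log units; within the scatter) for that swap. Nothing available explains the effect of the lost methyl.

As far as these compounds go, how an amine or a carboxylic acid in place of the hydroxy would score remains open, as does a longer chain on the oxygen, such as ethoxy.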